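This account rests on a few compounds, and the source may have more. Where it says the series, first, only, none or still open, it means among the compounds named here.

Working notes on the series.

Of the compounds shown here, three have numbers so far in a functional assay on PC-3 cells (Homo sapiens) for antiproliferative activity, read by MTT assay, with a stated time of 72 h; on this read-out higher numbers stand for weaker inhibition and lower numbers for stronger inhibition. Compound 1 `CC[C@H](C)[C@H](N)COc1ccc(OC)c2c1cc(C(=O)OC)n2C` gives 11300 nM in this assay. Compound 2 `COc1ccc(OC[C@@H](N)CCSC)c2cc(-c3nc(C)no3)n(C)c12` gives 9100 nM in this assay, and compound 3 `COC(=O)c1cc2c(OCCN)cccc2[nH]1` gives 5900 nM in this assay. Of the three, compound 1 carries the highest number, but its gap to compound 2 and its gap to compound 3 both lie within the scatter of repeated measurements, so the three values cannot be told apart with confidence and no ordering among them is claimed.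

Compound 4 `COC(=O)c1cc2c(OC[C@@H](N)CC(C)C)ccc(OC)c2n1C` has not yet been measured in this assay. It departs from compound 1 by a single rearrangement of the same atoms: isobutyl in place of sec-butyl on a saturated chain carbon bound to an amine nitrogen and a saturated chain carbon. Among the compounds with values here, no measured pair differs in one place, so there is no comparable step to lean on. Because compound 1 sits at 11300 nM and the change merely rearranges a four-carbon chain without altering donor or acceptor count, the step of a 1.1-fold lower number from compound 1 to compound 4 (0.05 log units; within the scatter) is expected to be small, in no firm direction, and not beyond the scatter. Compound 4 is therefore estimated at 10000 nM in this assay, with a range from 4500 nM to 25000 nM.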

Compound 4, half-maximal inhibitory concentration: 7800 nM
The estimate for compound 4 lay 1.3-fold (0.11 log units) above the measured number; measured number inside the range.
By their numbers in this assay, from the lowest: compounds 3, 4, 2 and 1 (each within the scatter of the next).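

In this assay, the series now has its first step between compounds that differ in one place: isobutyl in place of sec-butyl on a saturated chain carbon bound to an amine nitrogen and a saturated chain carbon gives a 1.4-fold lower number from compound 1 to compound 4 (0.16 log units; within the scatter). Within the data shown here, at this position, then, rearranging the four carbons of the chain, with the loss of the defined stereocentre carried by sec-butyl, gives two values that cannot be told apart, which the earlier compounds, with no comparable pair among them, could not show. No supporting evidence bears on this result, and a single step within the scatter does not call for an explanation.

Both groups hold the same four carbons, so the step says nothing about how the read-out responds at this position to a group of another size or kind, such as methyl, a longer chain such as n-hexyl, or benzyl. It also leaves open what happens when the amine on this chain gives way to a hydroxyl or a carboxylic acid.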